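Swapping a Chlorine for Two Methyl Groups

The compounds below may be only part of what the source reports. "The series", "measured", "known", "first", "only" and "open" are said of these compounds alone.

Compound 1 `NC1=NC2(CCOCC2)N(OCCCOc2cccc(Cl)c2)C(N)=N1`: 120 nM
Compound 2 `NC1=NC2(CCOCC2)N(OCCCOc2ccccc2Cl)C(N)=N1`: 70 nM
Compound 3 `NC1=NC2(CCOCC2)N(OCCCOc2ccccc2Br)C(N)=N1`: 30 nM

All three were tested in a functional assay on HCT-116 cells (Homo sapiens) for antiproliferative activity, read by MTT assay, with a stated time of 72 h; a higher number here means a weaker inhibitor, a lower number a stronger inhibitor. Compound 1 has the highest of the three numbers, so it is the weakest inhibitor on the numbers shown. The nearest is compound 2, reached by a 1.7-fold lower number from compound 1 to compound 2 (0.23 log units; within the scatter), a change too small to count. The furthest is compound 3, reached by a 4.0-fold lower number from compound 1 to compound 3 (0.60 log units; beyond the scatter); the step between the two halogens, a 2.3-fold lower number from compound 2 to compound 3 (0.37 log units; beyond the scatter), is also modest but real.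

Compound 4 `Cc1cc(C)cc(OCCCON2C(N)=NC(N)=NC23CCOCC3)c1` is a new variation on compound 1. The change is 3,5-dimethylphenyl in place of 3-chlorophenyl on an oxygen on a saturated carbon. Going by the values given here, no measured step touches a methyl group, so nothing measured bears directly on this change. Among the compounds with values here, the three measured steps show that moving or exchanging the halogen on this ring shifts the number by small to modest amounts only, and that is the only guide available. The expectation is therefore a step of about no change at the digits printed from compound 1 to compound 4 (within the scatter) in this assay, meaning no change beyond the scatter, with a wide range to allow for the lack of a direct precedent. Compound 4 is estimated at 120 nM, between 40 nM and 360 nM.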

Compound 4, half-maximal inhibitory concentration: 190 nM
Estimate against measurement, compound 4: 1.6-fold (0.20 log units) below, within the range that was stated.
By their numbers in this assay, from the lowest: compound 3; then compounds 2, 1 and 4 (each within the scatter of the next, the first and the last beyond it).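

Exchanging the 3-chlorophenyl for the 3,5-dimethylphenyl in this assay gives a 1.6-fold higher number from compound 1 to compound 4 (0.20 log units; within the scatter), so on this evidence a halogen on the ring is not required to keep the number close to that of compound 1, and two methyl groups can stand in for the single chlorine. The 2-halophenyl compounds nevertheless remain clearly ahead of the new compound, with a 2.7-fold higher number from compound 2 to compound 4 (0.43 log units; beyond the scatter) and the largest gap in the set, a 6.3-fold higher number from compound 3 to compound 4 (0.80 log units; beyond the scatter), so the dimethyl ring offers no gain over either of them. No information is available here to explain any of these differences.

Because one chlorine leaves and two methyl groups enter in a single step, the compounds shown cannot separate what each methyl group contributes, so a phenyl ring carrying only one methyl group would be the informative comparison. Going by these compounds, it also remains open whether a methoxy group or an amine on the ring, or a longer chain between the ring and the shared core, would keep the number near that of compound 1.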